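A few compounds are considered here, and "the series" means these few. Any claim that something is new, unique, unknown or untested is made for them only; others in the source may bear on it.

Measured in a functional assay on PC-3 cells (Homo sapiens) for antiproliferative activity, read by WST assay, with a stated time of 3 days; on this read-out lower numbers stand for stronger inhibition and higher numbers for weaker inhibition:
compound 1 `CCCOc1c(-c2cc(OC)c(OC)c(OC)c2)oc2ccccc2c1=O`: 11800 nM
compound 2 `CCCN(CCC)CCCOc1c(-c2cc(OC)c(OC)c(OC)c2)oc2ccccc2c1=O`: 16800 nM
compound 3 `CCCCN(CCCC)CCCCOc1c(-c2cc(OC)c(OC)c(OC)c2)oc2ccccc2c1=O`: 5300 nM

Compound 3, at 5300 nM, has the lowest of the three numbers, and its gaps to the other two lie beyond the scatter. The next compound is compound 4 `CCCCCN(CCCCC)CCCOc1c(-c2cc(OC)c(OC)c(OC)c2)oc2ccccc2c1=O`, which carries dipentylamino in place of (dibutylamino)methyl on a saturated chain carbon, three bonds along the chain from an oxygen on an aromatic ring.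

Three measured steps involve this same place. The closest guide is a 3.2-fold lower number from compound 2 to compound 3 (0.50 log units; beyond the scatter), a modest change. The other step reaching compound 3, a 2.2-fold lower number from compound 1 to compound 3 (0.35 log units; beyond the scatter), is also modest, while a 1.4-fold higher number from compound 1 to compound 2 (0.15 log units; within the scatter) stays within the scatter. Within the data shown here, the entering and leaving groups here are both open chains and close in size, and no measured step compares groups this similar. No step beyond the scatter is therefore expected in this assay. The expected step is a 1.1-fold higher number from compound 3 to compound 4 (0.05 log units; within the scatter). For compound 4 the estimated value is 6000 nM, with an expected range of 2500 nM to 14000 nM.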

Compound 4, half-maximal inhibitory concentration: 5800 nM
Beside the measured number, compound 4's estimate is 1.0-fold (0.01 log units) above it; measured number inside the range.
By their numbers in this assay, from the lowest: compounds 3 and 4 (each within the scatter of the next); then compounds 1 and 2 (each within the scatter of the next).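

In this assay, the exchange of (dibutylamino)methyl for dipentylamino at this place leaves the number unchanged within the scatter, with a 1.1-fold higher number from compound 3 to compound 4 (0.04 log units; within the scatter) as the step. The lower number is thus no longer tied to compound 3 alone: a 2.9-fold lower number from compound 2 to compound 4 (0.46 log units; beyond the scatter) and a 2.0-fold lower number from compound 1 to compound 4 (0.31 log units; beyond the scatter) both lie beyond the scatter, although compound 2 stays within the scatter of compound 1, so the trend is not a steady one across the series. Nothing on hand accounts for these differences.

Open, from the compounds shown here alone, is whether a longer chain on the nitrogen, such as dihexylamino, keeps these numbers or whether they rise again. Also open, going by these compounds, is how a ring amine such as piperidine or morpholine would compare at this place.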